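This account rests on a few compounds, and the source may have more. Where it says the series, first, only, none or still open, it means among the compounds named here.

Working notes on the series. Compound 1 `COc1ccc(-c2cc(NO)c(C(=O)Nc3ccccc3)c(=O)o2)cc1`, compound 2 `O=C(Nc1ccc(O)cc1)c1c(NO)cc(-c2ccccc2)oc1=O` and compound 3 `COC(=O)c1ccc(NC(=O)c2c(NO)cc(-c3ccccc3)oc2=O)cc1` share one core and differ only in the group on the amide nitrogen. In an ADME assay on Huh-7 cells (Homo sapiens) for cytotoxicity, read by a luciferase reporter and WST assay, with a stated time of 3 days (a lower number here means that less compound is tolerated, a higher number that more compound is tolerated), compound 1 gives 16200 nM. For compound 2 the value in this assay is a limit of the assay, > 20000 nM. For compound 3 the value in this assay is likewise a limit, > 20000 nM. For the measured compounds named here, the step that the two limits leave unreadable from compound 2 to compound 3 therefore cannot be sized; both values sit at the limit of > 20000 nM in this assay, at which 2 of the 3 values shown sit, and this is all the measured steps offer. Compound 4 `CNC(=O)c1c(NO)cc(-c2ccccc2)oc1=O` is not yet measured in this assay. It differs from compound 2 by methyl in place of 4-hydroxyphenyl on an amide-type nitrogen, that is, (4-hydroxyphenyl)amino becomes methylamino. Going by the values given here, no measured step covers this change; the only bearing is that compound 2 sits at the limit and that compound 1 alone gives a number rather than a limit. The expected step that the limit leaves unreadable from compound 2 to compound 4 is accordingly none beyond the scatter. Compound 4 is thus estimated at 25000 nM in this assay, within 8000 nM to 80000 nM, most likely returned as a limit once more.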

Compound 4, half-maximal cytotoxic concentration: > 20000 nM
Compound 4 was reported as a limit (the forecaster's own chance of this, stated with the estimate: 70%); the middle value lies beyond the limit too.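

Compound 4 also returns only a limit, > 20000 nM. Compound 2 is likewise a limit, so no step between compound 2 and compound 4 can be read: the limit of > 20000 nM in this assay, at which 3 of the 4 values shown sit.

The compounds shown leave open whether methyl in place of 4-hydroxyphenyl changes how much compound is tolerated at all.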